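Sulfamate series: benzyl swap at the aniline nitrogen

The compounds below may be only part of what the source reports. "The series", "measured", "known", "first", "only" and "open" are said of these compounds alone.

Compound 1 `CCN(Cc1cccnc1)c1ccc(C(=O)N2CCc3ccc(OS(N)(=O)=O)cc3C2)cc1` gives 85.2% in an assay on HEK293 cells for inhibition of Steryl-sulfatase (Homo sapiens), tested at 1 uM; a higher number here means a stronger effect of the compound at the concentration tested, a lower number a weaker effect. Compound 2 `CCN(Cc1ccccn1)c1ccc(C(=O)N2CCc3ccc(OS(N)(=O)=O)cc3C2)cc1` gives 87.7% in the same measurement. Going by the values given here, the single measured step is a number 2.5 percentage points higher from compound 1 to compound 2 (within the scatter), so compound 2 stands level with compound 1; the two numbers lie within the scatter of each other and neither can be ranked above the other.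

Compound 3 `CCN(Cc1ccc(Br)cc1)c1ccc(C(=O)N2CCc3ccc(OS(N)(=O)=O)cc3C2)cc1` is the next member. Its change from compound 2 is 4-bromophenyl in place of pyridin-2-yl on a saturated chain carbon bound to a nitrogen on an aromatic ring. Among the compounds with values here, only the step from compound 1 to compound 2 bears on this change, and it compares two pyridyl groups at the same place; it gives no information on exchanging the ring nitrogen for a carbon-only ring carrying bromine. That step was small, and the two pyridyl isomers read alike, which points to the group on the saturated chain carbon bound to the aromatic nitrogen tolerating variation. Within the data shown here, with no measured step covering the bromophenyl, the expectation for compound 3 is a number 3.7 percentage points lower from compound 2 to compound 3 (within the scatter), that is, no change beyond the scatter. Compound 3 is therefore estimated at 84%, with a range from 68% to 95%.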

Compound 3, a percentage reported as inhibition, at one concentration (the size of the read-out at that concentration, not a potency): 95.9%
The estimate for compound 3 lay 11.9 percentage points below the measured number, outside the stated range (above it).
By their numbers in this assay, from the lowest: compounds 1, 2 and 3 (each within the scatter of the next, the first and the last beyond it).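

Exchanging a pyridyl ring for 4-bromophenyl on a saturated chain carbon bound to a nitrogen on an aromatic ring leaves the read-out in this assay high, so a ring nitrogen is not required here for a large effect at the single concentration tested. The two pyridyl comparisons do not read alike: the step is a number 8.2 percentage points higher from compound 2 to compound 3 (within the scatter), whereas it is a number 10.7 percentage points higher from compound 1 to compound 3 (beyond the scatter), so a modest gain for the bromophenyl group holds only against pyridin-3-yl, and compound 2 goes against any general ranking of bromophenyl over pyridyl. No measurement shown here accounts for the difference between these rings.

Still open, going by these compounds, is whether the bromine or the carbon-only ring matters more, which a plain phenyl group or a chlorine in place of the bromine would help to separate. Also open is how far this place tolerates other kinds of group, such as a carboxylic acid or an amine on the ring or a saturated cyclohexyl ring, and how the effects of these compounds would compare at concentrations other than the single one tested.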